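Aryl swap on the carbonyl carbon: compound 4

The source may hold more compounds than are shown below. What is called first, only, known or untested is meant among the compounds shown, and "the series" means these compounds.

The series shares one core, seen in compound 1 `COc1cc(-c2cc(/C=C/C(=O)c3ccc(N)cc3)[nH]n2)cc(OC)c1OC`, compound 2 `COc1ccc(-c2cc(/C=C/C(=O)c3cc(OC)c(OC)c(OC)c3)[nH]n2)cc1OC` and compound 3 `COc1ccc(C(=O)/C=C/c2cc(-c3cc(OC)c(OC)c(OC)c3)n[nH]2)cc1OC`. In a functional assay on LOX IMVI cells (Homo sapiens) for inhibition, read by sulforhodamine B assay, with a stated time of 48 h (a lower number here means a stronger inhibitor of growth, a higher number a weaker inhibitor of growth), compound 1 gives 3280 nM, compound 2 gives 2880 nM and compound 3 gives 2760 nM. Compound 1 has the highest of the three numbers, but its nearest neighbour compound 2 and its furthest neighbour compound 3 both sit within the scatter of it, so no order among the three is claimed. Going by the values given here, the one measured step that changes the group on the carbonyl carbon, a 1.2-fold lower number from compound 1 to compound 3 (0.07 log units; within the scatter), is within the scatter.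

Compound 4 `COc1cc(-c2cc(/C=C/C(=O)c3ccc(F)c(F)c3)[nH]n2)cc(OC)c1OC` differs from compound 1 in one place: 3,4-difluorophenyl in place of 4-aminophenyl on a carbonyl carbon. Among the compounds with values here, no measured compound carries a 3,4-difluorophenyl group, so the only step that bears on this change is a 1.2-fold lower number from compound 1 to compound 3 (0.07 log units; within the scatter), and it showed nothing beyond the scatter. On that basis no step beyond the scatter is expected in this assay, in either direction. Compound 4 is therefore estimated at 3000 nM, with a range from 1200 nM to 8000 nM. This estimate for compound 4 means an expected step of a 1.1-fold lower number from compound 1 to compound 4 (0.04 log units; within the scatter).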

Compound 4, concentration for total growth inhibition: 12200 nM
Compound 4: middle estimate off by 4.1-fold (0.61 log units), on the low side, outside the stated range (above it).
By their numbers in this assay, from the lowest: compounds 3, 2 and 1 (each within the scatter of the next); then compound 4.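

In this assay the group on the carbonyl carbon is now seen to matter: a 3.7-fold higher number from compound 1 to compound 4 (0.57 log units; beyond the scatter), and a 4.4-fold higher number from compound 3 to compound 4 (0.65 log units; beyond the scatter). The 4-aminophenyl and 3,4-dimethoxyphenyl groups remain within the scatter of each other, a 1.2-fold lower number from compound 1 to compound 3 (0.07 log units; within the scatter), so this position tolerates those two groups alike but not 3,4-difluorophenyl, and the step is towards weaker growth inhibition, with no group yet giving a step to a lower number. Nothing on hand accounts for this step.

The compounds shown leave open whether the step comes with one fluorine or needs both, which a 4-fluorophenyl group would test. They also leave open whether any group at this position, such as 4-hydroxyphenyl or 4-chlorophenyl, moves the number lower than the amine and dimethoxy compounds.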